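Amide aryl variation on a shared core

The source may hold more compounds than are shown below. What is called first, only, known or untested is meant among the compounds shown, and "the series" means these compounds.

Measured in a functional assay on MIA PaCa-2 cells (Homo sapiens) for inhibition, read by MTT assay; a lower number here means a stronger inhibitor, a higher number a weaker inhibitor:
compound 1 `O=C(Nc1ccccc1)c1cc2cnc(Nc3ccc(N4CCNCC4)cn3)nc2n1C1CCCC1` — 2800 nM
compound 2 `O=C(Nc1ccc[n+]([O-])c1)c1cc2cnc(Nc3ccc(N4CCNCC4)cn3)nc2n1C1CCCC1` — 125000 nM
compound 3 `COc1ccccc1NC(=O)c1cc2cnc(Nc3ccc(N4CCNCC4)cn3)nc2n1C1CCCC1` — 1830 nM

Compound 3 sits with compound 1, the step of a 1.5-fold lower number from compound 1 to compound 3 (0.18 log units; within the scatter) lying within the scatter, and far from compound 2, as a 68-fold lower number from compound 2 to compound 3 (1.83 log units; beyond the scatter) shows; the only large movement in the series is a 45-fold higher number from compound 1 to compound 2 (1.65 log units; beyond the scatter).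

Compound 4 `COc1cccc(NC(=O)c2cc3cnc(Nc4ccc(N5CCNCC5)cn4)nc3n2C2CCCC2)c1` differs from compound 3 by 3-methoxyphenyl in place of 2-methoxyphenyl on an amide-type nitrogen. Among the measured compounds shown here, no measured step shifts a methoxy between positions, and the one step that touches the methoxy, a 1.5-fold lower number from compound 1 to compound 3 (0.18 log units; within the scatter), is within the scatter. The step expected in this assay is therefore small, without a clear direction. Compound 4 is estimated at 2000 nM, expected between 800 nM and 5000 nM. The expected step is a 1.1-fold higher number from compound 3 to compound 4 (0.04 log units; within the scatter).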

Compound 4, half-maximal inhibitory concentration: 2650 nM
Beside the measured number, compound 4's estimate is 1.3-fold (0.12 log units) below it; low and high end bracket the measured number.
By their numbers in this assay, from the lowest: compounds 3, 4 and 1 (each within the scatter of the next); then compound 2.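

In this assay, the methoxy position on the ring makes no readable difference: 3-methoxyphenyl in place of 2-methoxyphenyl gives a 1.4-fold higher number from compound 3 to compound 4 (0.16 log units; within the scatter), and methoxy in place of hydrogen at this new position gives a 1.1-fold lower number from compound 1 to compound 4 (0.02 log units; within the scatter). The large gap holds for this position too, with a 47-fold lower number from compound 2 to compound 4 (1.67 log units; beyond the scatter). No supporting evidence bears on these results.

Still open, on these data alone, is whether a plain pyridine ring on the amide-type nitrogen would show the same large step. Also open, as far as these compounds go, is how an amine or a carboxylic acid on the phenyl ring would read here.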